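The source may report more compounds than this note shows. Statements on the series, on what has been measured and on what is new or still open speak of the compounds shown alone.

In a physicochemical assay for permeability, using PAMPA (a lower number here means that the compound crosses the layer more slowly, a higher number that the compound crosses the layer faster), compound 1 `COCCOc1cc2oc(=O)n(CCC(=O)O)c2cc1Cl` gives < 3 nm/s as a limit and not a number. For the measured compounds named here, compound 2 `C[C@@H](Oc1cc2oc(=O)n(CCC(=O)O)c2cc1Cl)c1ccc(F)cn1` gives 31 nm/s as the only actual number so far. Compound 3 `Cc1ccc([C@@H](C)Oc2cc3oc(=O)n(CCC(=O)O)c3cc2Cl)nc1` differs from compound 2 by methyl in place of fluoro on an aromatic carbon with methyl in place of fluoro on an aromatic carbon, para to a large group. Going by the values given here, no measured step bears on this change. In this assay no step beyond the scatter is expected in either direction, and a 1.1-fold higher number from compound 2 to compound 3 (0.05 log units; within the scatter) is the estimated size. Compound 3 is estimated at 35 nm/s with an expected range of 14 nm/s to 85 nm/s for repeat measurements.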

Compound 3, apparent permeability: 22 nm/s
Beside the measured number, compound 3's estimate is 1.6-fold (0.20 log units) above it; low and high end bracket the measured number.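

In this assay, for the compounds shown here, the change from 5-fluoropyridin-2-yl to 5-methylpyridin-2-yl, on an aromatic carbon two atoms from the ring nitrogen, gives a 1.4-fold lower number from compound 2 to compound 3 (0.15 log units; within the scatter) as the first readable step. Methyl and fluoro at this position therefore cannot be ordered in this read-out. The data shown give no cause for this step.

Compound 1 gives < 3 nm/s as a limit and not a number, so steps to it cannot be read. On these data alone, how an amine or a longer chain at this position reads in this assay remains open.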